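Compound 3 to compound 4: a benzyl swap on the amide

A few compounds are considered here, and "the series" means these few. Any claim that something is new, unique, unknown or untested is made for them only; others in the source may bear on it.

In a functional assay on A2780 cells (Homo sapiens) for antiproliferative activity, read by resazurin assay, with a stated time of 72 h (a higher number here means a weaker inhibitor, a lower number a stronger inhibitor), compound 1 (`NC(=O)c1cc2c(Cc3ccccc3)n[nH]c2cc1O`) stands as "not determined" (no result reported) and offers no number. Compound 2 (`CN(C(=O)c1cc2c(Cc3ccccc3)n[nH]c2cc1O)c1ccco1`) gives 2500 nM and compound 3 (`CN(Cc1cccc(F)c1)C(=O)c1cc2c(Cc3ccccc3)n[nH]c2cc1O`) gives 5000 nM in the same read-out. Among the compounds with values here, the only measured step is a 2.0-fold higher number from compound 2 to compound 3 (0.30 log units; within the scatter) and it shows no trend. Compound 3 thus sits level with compound 2. Compound 4 (`CN(Cc1ccc(Br)cc1)C(=O)c1cc2c(Cc3ccccc3)n[nH]c2cc1O`) carries 4-bromophenyl in place of 3-fluorophenyl on a saturated chain carbon bound to an amide-type nitrogen. Within the data shown here, the one measured swap at this nitrogen stayed within the scatter, so the expected outcome is a 1.3-fold lower number from compound 3 to compound 4 (0.10 log units; within the scatter) with no move beyond the scatter in this assay in either direction. Compound 4 is estimated at 4000 nM (expected range 1500 nM to 10000 nM).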

Compound 4, half-maximal inhibitory concentration: 2800 nM
The estimate for compound 4 lay 1.4-fold (0.15 log units) above the measured number; measured number inside the range.
By their numbers in this assay, from the lowest: compounds 2, 4 and 3 (each within the scatter of the next).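

In this assay, 4-bromophenyl in place of 3-fluorophenyl gives a 1.8-fold lower number from compound 3 to compound 4 (0.25 log units; within the scatter), and 4-bromobenzyl in place of furan-2-yl gives a 1.1-fold higher number from compound 2 to compound 4 (0.05 log units; within the scatter). This amide-type nitrogen has now carried furan-2-yl, 3-fluorobenzyl and 4-bromobenzyl with no step beyond the scatter, so the halogen change on the benzyl group does not separate these compounds. Nothing available explains this flat reading. Open, as far as these compounds go, is whether an amine or a carboxylic acid on the phenyl ring, or a longer chain on this nitrogen, would move the number beyond the scatter. Compound 1, at "not determined" (no result reported), gives no reading for the primary amide.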